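This account rests on a few compounds, and the source may have more. Where it says the series, first, only, none or still open, it means among the compounds named here.

Compound 1 `Cc1ccc2[nH]c(=O)c(-c3nc4cc([N+](=O)[O-])ccc4[nH]3)cc2c1` carries a nitro group on its fused ring system. In a functional assay on SK-OV-3 cells (Homo sapiens) for cytotoxicity, read by MTT assay, with a stated time of 48 h (on this read-out higher numbers stand for weaker inhibition and lower numbers for stronger inhibition), compound 1 gives only a limit, > 100000 nM. Going by the values given here, compound 2 `Cc1ccc2[nH]c(=O)c(-c3nc4cc(Cl)ccc4[nH]3)cc2c1` is the single member of the pair with a real number: in this assay compound 2 gives 33000 nM. Among the compounds with values here, the step of an at least 3.0-fold lower number from compound 1 to compound 2 (0.48 log units; beyond the scatter) is the only measured comparison, and it rests on the limit (the limit of > 100000 nM in this assay, at which 1 of the 2 values shown sits). Compound 3 `Cc1ccc2[nH]c(=O)c(-c3nc4cc(Br)ccc4[nH]3)cc2c1` differs from compound 2 by bromo in place of chloro on an aromatic carbon. Within the data shown here, no measured step covers one halogen replacing another, so the step of a 1.1-fold lower number from compound 2 to compound 3 (0.04 log units; within the scatter) is expected to stay within the scatter. Compound 3 is estimated at 30000 nM, between 12000 nM and 80000 nM.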

Compound 3, half-maximal inhibitory concentration: > 100000 nM
Compound 3: no number, only a limit (the forecaster's own chance of this, stated with the estimate: 15%); at least 3.3-fold (0.52 log units) between middle value and limit.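

Halogens are not interchangeable at this aromatic carbon: bromo in place of chloro gives an at least 3.0-fold higher number from compound 2 to compound 3 (0.48 log units; beyond the scatter). Going by these compounds alone, the first measured step showed only that chloro reads differently from nitro, whereas this one separates two halogens, leaving compound 2 as the only one of the three compounds with a real number. This step rests on a limit, and the step from compound 1 to compound 3 cannot be read: the limit of > 100000 nM in this assay, at which 2 of the 3 values shown sit.

Open, from the compounds shown here alone, is how fluoro, an amine or a methoxy group at this carbon would read in this assay. Also open, going by these compounds, is how large the step from compound 2 to compound 3 really is.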